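The compounds below may be only part of what the source reports. "The series", "measured", "known", "first", "only" and "open" are said of these compounds alone.

Three compounds share one core and differ only in the group on the aromatic carbon that lies between two ring nitrogen atoms of the five-membered ring. Compound 1 `Cc1nc2nc(C)c(CN)c(-c3ccc(Cl)cc3Cl)n2n1` carries a methyl there. In an assay on isolated protein for inhibition of Dipeptidyl peptidase 9 (Homo sapiens) (on this read-out lower numbers stand for stronger inhibition and higher numbers for weaker inhibition), compound 1 gives only the limit > 30000 nM and no number. Compound 2 `CCN(CC)c1nc2nc(C)c(CN)c(-c3ccc(Cl)cc3Cl)n2n1` carries diethylamino; in this assay compound 2 likewise gives only the limit > 30000 nM. Compound 3 `Cc1nc2nc(N3CCCC3)nn2c(-c2ccc(Cl)cc2Cl)c1CN` carries pyrrolidin-1-yl; in this assay compound 3 again gives only the limit > 30000 nM. The steps a step that the two limits leave unreadable from compound 1 to compound 2, a step that the two limits leave unreadable from compound 1 to compound 3 and a step that the two limits leave unreadable from compound 2 to compound 3 therefore have no readable size, because the limit of > 30000 nM in this assay, at which 3 of the 3 values shown sit, holds all three values. Compound 4 `Cc1nc2nc(-c3ccccc3)nn2c(-c2ccc(Cl)cc2Cl)c1CN` changes compound 3 by phenyl in place of pyrrolidin-1-yl on an aromatic carbon. For the measured compounds named here, none of the measured steps gives a direction, so the expected step of a number no higher from compound 3 to compound 4 (the limit leaves the size open) rests on no measured change. Compound 4 is estimated at 30000 nM, between 8000 nM and 120000 nM, most likely once more a limit.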

Compound 4, inhibition constant: > 30000 nM
Compound 4 was reported as a limit; the forecaster's own chance of this, stated with the estimate: 70%; the middle value lies on the limit itself.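

No step from compound 1, compound 2 or compound 3 to compound 4 can be read, because each value is a limit and not a number: the limit of > 30000 nM in this assay, at which 4 of the 4 values shown sit.

How strongly any of these compounds acts in this assay, and whether the group at this place matters, stays open.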